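The source may hold more compounds than are shown below. What is called first, only, known or untested is meant among the compounds shown, and "the series" means these compounds.

Measured so far:
compound 1, `Cc1cn([C@@H]2O[C@H](CO[Si](C)(C)C(C)(C)C)[C@@]3(OS(=O)(=O)C=C3NCC(=O)C(=O)O)[C@H]2O[Si](C)(C)C(C)(C)C)c(=O)n(C)c1=O`: 400000 nM
compound 2, `Cc1cn([C@@H]2O[C@H](CO[Si](C)(C)C(C)(C)C)[C@@]3(OS(=O)(=O)C=C3NC(=O)NC(=O)c3ccccc3)[C@H]2O[Si](C)(C)C(C)(C)C)c(=O)n(C)c1=O`: >= 80000 nM

In a functional assay on HEL cells (Homo sapiens) for cytotoxicity, read by microscopy (on this read-out lower numbers stand for higher toxicity in this test and higher numbers for lower toxicity in this test), compound 1 gives 400000 nM. Compound 2 is reported only as a limit, >= 80000 nM, and not as a number. That limit, (the limit of >= 80000 nM in this assay, at which 1 of the 2 values shown sits), is where compound 2 stands; its true value is not pinned down. For the measured compounds named here, the only step in the set, a step that the limit leaves unreadable from compound 1 to compound 2, is consequently of unreadable size, and it tells nothing about direction either.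

Compound 3, `Cc1cn([C@@H]2O[C@H](CO[Si](C)(C)C(C)(C)C)[C@@]3(OS(=O)(=O)C=C3NCCC(=O)OCc3ccccc3)[C@H]2O[Si](C)(C)C(C)(C)C)c(=O)n(C)c1=O`, is not yet measured. Its change from compound 2 is 2-(benzyloxycarbonyl)ethyl in place of benzoylcarbamoyl on an amine nitrogen. Going by the values given here, no measured step covers this change, and the one step that exists cannot be read, so there is no basis for expecting a shift beyond the scatter in either direction. What the two measured compounds do show is that both sit at weak cytotoxicity.

Compound 3 is therefore expected to come out near 150000 nM, with a range from 40000 nM to 400000 nM. The step expected in this assay is a step that the limit leaves unreadable from compound 2 to compound 3, and a second limit rather than a number is a real possibility.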

Compound 3, minimum cytotoxic concentration: >= 400000 nM
Compound 3 was reported as a limit; the forecaster's own chance of this, stated with the estimate: 45%; middle value at least 2.6-fold (0.42 log units) away from the limit.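

In this assay compound 3 is reported only as a limit, >= 400000 nM. As far as these compounds go, the set now holds one step with a direction, a number no lower from compound 1 to compound 3 (the limit leaves the size open), so (benzyloxycarbonyl)methyl in place of carboxycarbonyl on the saturated chain carbon bound to the amine nitrogen gives no sign of higher toxicity in this test, though the size of the step stays open. The other step between the two limits cannot be read, and the order of compound 2 and compound 3 remains undetermined.

For the compounds shown here, only one of the three values is a number, and it remains open whether any group on this amine nitrogen can bring the minimum cytotoxic concentration in this assay down to a measurable lower value. A plain carboxylic acid on a longer chain, or a primary amine at the end of such a chain, on the same nitrogen would test whether the ester of compound 3 and the carboxycarbonyl of compound 1 differ at all on this read-out.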